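From Chloro to Methoxy: Estimating Compound 3

A few compounds are considered here, and "the series" means these few. Any claim that something is new, unique, unknown or untested is made for them only; others in the source may bear on it.

Measured compounds:
compound 1, `Cc1ccc(-c2nnc(SCCOc3ccc(/C=C4\SC(=O)NC4=O)cc3)[nH]2)cc1`: 21.7%
compound 2, `O=C1NC(=O)/C(=C/c2ccc(OCCSc3nnc(-c4ccc(Cl)cc4)[nH]3)cc2)S1`: 24.6%

In a functional assay on the whole organism (strain Wistar) with Rattus norvegicus as the target, with a stated time of 15 days, at a dose of 10 mg/kg by the oral route (on this read-out lower numbers stand for a weaker effect and higher numbers for a stronger effect at the one dose given), compound 2 gives 24.6%, the top of the two measured numbers, while compound 1, at 21.7%, sits within the scatter of it, the step of a number 2.9 percentage points higher from compound 1 to compound 2 (within the scatter) being too small to count as a difference. Compound 3, `COc1ccc(-c2nnc(SCCOc3ccc(/C=C4\SC(=O)NC4=O)cc3)[nH]2)cc1`, is not yet measured and differs from compound 2 by methoxy in place of chloro on an aromatic carbon. For the measured compounds named here, the only measured step, a number 2.9 percentage points higher from compound 1 to compound 2 (within the scatter), exchanged two other groups on an aromatic carbon and stayed within the scatter; no measured compound carries a methoxy there, so nothing in the data points in either direction. The expectation is therefore no step beyond the scatter, with wide uncertainty. Compound 3 is expected to give about 23% in this assay, between 10% and 36%. For compound 3 this amounts to an expected step of a number 1.6 percentage points lower from compound 2 to compound 3 (within the scatter).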

Compound 3, a percentage reported as activity, at one dose (the size of the read-out at that dose, not a potency): 42.6%
Compound 3: the middle estimate sits 19.6 percentage points below what was measured; measured number outside the range, above it.
By their numbers in this assay, from the lowest: compounds 1 and 2 (each within the scatter of the next); then compound 3.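

In this assay, the aromatic carbon para to a large group proves responsive to the group it carries: methoxy in place of chloro gives a number 18 percentage points higher from compound 2 to compound 3 (beyond the scatter), and methoxy in place of methyl gives a number 20.9 percentage points higher from compound 1 to compound 3 (beyond the scatter). The earlier compounds shown here could not show this, since methyl and chloro at this carbon stayed within the scatter of each other, so the position had looked indifferent to change. Nothing available explains why methoxy stands apart from these two groups.

The compounds shown leave open whether the higher number depends on the oxygen, the added carbon or both, which a hydroxyl or an ethoxy on the same carbon could begin to separate. They also leave open how an amine or a carboxylic acid would fare there.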